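Removing a Trifluoromethyl Group from the Lowest-Scoring Compound

The source may report more compounds than this note shows. Statements on the series, on what has been measured and on what is new or still open speak of the compounds shown alone.

So far, three compounds sharing one core have been tested in a functional assay on OVCAR-5 cells (Homo sapiens) for inhibition, read by CCK-8 assay, with a stated time of 72 h, tested at 10 uM; on this read-out lower numbers stand for less inhibition of growth and higher numbers for more inhibition of growth at the one concentration tested. Compound 1 `CN(C)C(=O)c1cc2cnc(Nc3ccc(NC(=O)C4(C(=O)Nc5ccc(Cl)cc5)CC4)cc3)nc2n1C1CCCC1` gives 85.3%, and compound 2 `CN(C)C(=O)c1cc2cnc(Nc3ccc(NC(=O)C4(C(=O)Nc5ccc(Br)cc5)CC4)cc3)nc2n1C1CCCC1` gives 87.8%. Putting bromo in place of chloro on an aromatic carbon amounts to a number 2.5 percentage points higher from compound 1 to compound 2 (within the scatter), so this swap shows no real difference. Compound 3 `CN(C)C(=O)c1cc2cnc(Nc3ccc(NC(=O)C4(C(=O)Nc5ccc(Cl)c(C(F)(F)F)c5)CC4)cc3)nc2n1C1CCCC1` stands lowest of the three, at 48%. Trifluoromethyl in place of hydrogen on an aromatic carbon accounts for a number 37.3 percentage points lower from compound 1 to compound 3 (beyond the scatter). The comparison with the bromo compound gives a similar picture, a number 39.8 percentage points lower from compound 2 to compound 3 (beyond the scatter).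

Compound 4 `CN(C)C(=O)c1cc2cnc(Nc3ccc(NC(=O)C4(C(=O)Nc5ccc(O)cc5)CC4)cc3)nc2n1C1CCCC1` has not yet been measured. It differs from compound 3 as follows: 4-hydroxyphenyl in place of 4-chloro-3-(trifluoromethyl)phenyl on an amide-type nitrogen. The trifluoromethyl group leaves in this change, so the large step of a number 37.3 percentage points lower from compound 1 to compound 3 (beyond the scatter) would point to a higher number if it simply ran in reverse. The chlorine leaves as well, and the 4-hydroxyphenyl group has not been tested on this core, so a full return to the level of compound 1 cannot be assumed. The expected result in this assay is a moderate rise, a number 17 percentage points higher from compound 3 to compound 4 (beyond the scatter). Compound 4 is estimated at 65%, with an expected range from 38% to 88%.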

Compound 4, percent growth inhibition at one concentration: 90.9%
Beside the measured number, compound 4's estimate is 25.9 percentage points below it; the whole stated range lies below it.
By their numbers in this assay, from the lowest: compound 3; then compounds 1, 2 and 4 (each within the scatter of the next).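

In this assay, replacing the 4-chloro-3-(trifluoromethyl)phenyl group with 4-hydroxyphenyl on the amide-type nitrogen gives a number 42.9 percentage points higher from compound 3 to compound 4 (beyond the scatter) and brings the series back to the level of the two simple halogen compounds. The hydroxy compound cannot be told apart from either of them, with hydroxy in place of chloro giving a number 5.6 percentage points higher from compound 1 to compound 4 (within the scatter) and hydroxy in place of bromo giving a number 3.1 percentage points higher from compound 2 to compound 4 (within the scatter), so on this ring a chloro, a bromo and a hydroxy group all serve equally well in this read-out, and among the four compounds only compound 3, the one carrying trifluoromethyl, stands apart. Nothing measured on these compounds explains why the groups behave this way.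

On these data alone, whether an amine or a carboxylic acid in place of the hydroxy group would hold the number stays open, as does whether a trifluoromethyl group lowers it when paired with hydroxy rather than chloro. As far as these compounds go, because each compound was read at a single concentration, it also remains open whether compound 1, compound 2 and compound 4 would still match at lower concentrations.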